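The compounds below may be only part of what the source reports. "The series", "measured", "known", "first", "only" and "open" are said of these compounds alone.

Measured in an assay on CHO cells for antagonist activity at transient receptor potential cation channel subfamily V member 1 (Homo sapiens), read by FLIPR and calcium flux; on this read-out lower numbers stand for stronger inhibition and higher numbers for weaker inhibition:
compound 1 `CC(C(=O)NCc1ccc(C(F)(F)F)nc1Br)c1ccc(NS(C)(=O)=O)c(F)c1` — 169 nM
compound 2 `CCCCCCc1nc(C(F)(F)F)ccc1CNC(=O)C(C)c1ccc(NS(C)(=O)=O)c(F)c1` — 1.6 nM
compound 3 `CC(C)=Cc1nc(C(F)(F)F)ccc1CNC(=O)C(C)c1ccc(NS(C)(=O)=O)c(F)c1` — 11.5 nM

Compound 1 stands highest of the three numbers in this assay; compound 3 is nearest (a 15-fold lower number from compound 1 to compound 3 (1.17 log units; beyond the scatter)) and compound 2 furthest (a 110-fold lower number from compound 1 to compound 2 (2.02 log units; beyond the scatter)). Compound 4 `CCC/C=C\c1nc(C(F)(F)F)ccc1CNC(=O)C(C)c1ccc(NS(C)(=O)=O)c(F)c1` is not yet measured. It differs from compound 1 by pent-1-en-1-yl in place of bromo on an aromatic carbon. Both measured steps from compound 1 bear on it: each replaces bromo with a carbon chain on the same aromatic carbon and each gives a large drop. The entering group shares the chain length of hexyl and the double bond of 2-methylprop-1-en-1-yl, so compound 4 should land between compound 2 and compound 3, whose spread is a 7.2-fold higher number from compound 2 to compound 3 (0.86 log units; beyond the scatter). A large drop is therefore expected, a 48-fold lower number from compound 1 to compound 4 (1.68 log units; beyond the scatter). For compound 4 the estimated value is 3.5 nM, range 1.2 nM to 12 nM.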

Compound 4, inhibition constant: 2.1 nM
For compound 4 the middle estimate is 1.7-fold (0.22 log units) above the measured one, and the stated range covers the measured number.
By their numbers in this assay, from the lowest: compounds 2 and 4 (each within the scatter of the next); then compound 3; then compound 1.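

In this assay, pent-1-en-1-yl keeps the large gain over bromo (an 80-fold lower number from compound 1 to compound 4 (1.91 log units; beyond the scatter)) and cannot be told apart from hexyl (a 1.3-fold higher number from compound 2 to compound 4 (0.12 log units; within the scatter)), so a double bond in the chain does not by itself cost activity at this position. Pent-1-en-1-yl also differs from 2-methylprop-1-en-1-yl (a 5.5-fold lower number from compound 3 to compound 4 (0.74 log units; beyond the scatter)), so the weaker number of compound 3 does not follow from the double bond alone. No measured evidence accounts for these differences. Going by these compounds, whether an octyl chain, a phenyl ring or an amine on this carbon would hold these numbers stays open.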